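The source may hold more compounds than are shown below. What is called first, only, known or untested is meant among the compounds shown, and "the series" means these compounds.

Measured compounds in this series:
- compound 1, `Nc1scc(CN2CCN(c3ccc(F)cc3Cl)CC2)c1C(=O)c1ccc(Cl)cc1`: -70%
- compound 2, `Nc1scc(CN2CCN(c3cccc(F)c3)CC2)c1C(=O)c1ccc(Cl)cc1`: -82%
- compound 3, `Nc1scc(CN2CCN(c3ccc(F)c(F)c3)CC2)c1C(=O)c1ccc(Cl)cc1`: -87%

In a functional assay on CHO cells with adenosine receptor A1 (Homo sapiens) as the target, read by cAMP accumulation and immunoassay, with a stated time of 6 min, tested at 10 uM (on this read-out higher numbers stand for a weaker effect at the one concentration tested and lower numbers for a stronger effect), compound 3 gives -87%, the lowest of the three numbers. Compound 2 gives -82%, and the step of a number 5 percentage points lower from compound 2 to compound 3 (within the scatter) lies within the scatter, so the two cannot be ordered. Compound 1 gives -70%; the steps of a number 12 percentage points lower from compound 1 to compound 2 (beyond the scatter) and a number 17 percentage points lower from compound 1 to compound 3 (beyond the scatter) are both beyond the scatter and of modest size, so compound 3 stands clearly apart from compound 1 only.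

Compound 4, `Nc1scc(CN2CCN(c3cc(F)cc(F)c3)CC2)c1C(=O)c1ccc(Cl)cc1`, differs from compound 3 by 3,5-difluorophenyl in place of 3,4-difluorophenyl on an amine nitrogen in a ring. The step that bears most directly on this change is a number 5 percentage points lower from compound 2 to compound 3 (within the scatter), within the scatter: a fluoro in place of hydrogen on an aromatic carbon of this phenyl made no measurable difference. The larger steps of a number 12 percentage points lower from compound 1 to compound 2 (beyond the scatter) and a number 17 percentage points lower from compound 1 to compound 3 (beyond the scatter) each replace the 2-chloro-4-fluorophenyl as a whole and so say little about shifting one fluorine between two positions on a phenyl that keeps both fluorines. No step beyond the scatter is therefore expected, and the estimated step is a number 3 percentage points higher from compound 3 to compound 4 (within the scatter). Compound 4 is expected to give -84%, with a range from -97% to -68%.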

Compound 4, a percentage reported as activity, at one concentration (the size of the read-out at that concentration, not a potency): -79%
The estimate for compound 4 lay 5 percentage points below the measured number; low and high end bracket the measured number.
By their numbers in this assay, from the lowest: compounds 3, 2, 4 and 1 (each within the scatter of the next, the first and the last beyond it).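

In this assay, the step of a number 8 percentage points higher from compound 3 to compound 4 (within the scatter) shows that the 3,5-difluorophenyl and the 3,4-difluorophenyl on the amine nitrogen in the ring cannot be told apart, and the step of a number 3 percentage points higher from compound 2 to compound 4 (within the scatter) likewise leaves the 3,5-difluorophenyl unresolved from the 3-fluorophenyl of compound 2. What is new is the step of a number 9 percentage points lower from compound 1 to compound 4 (within the scatter): among the replacements of the 2-chloro-4-fluorophenyl, this is the only one that stays within the scatter, so the clear separation from compound 1 seen for compound 2 and compound 3 does not extend to every fluorinated phenyl at this position. No measurement on hand accounts for this result.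

What a 3,5-dichlorophenyl, a methoxyphenyl or an unsubstituted phenyl would give on this nitrogen remains open, as all four groups shown here are halogenated phenyls. From the compounds shown here alone, the 4-chlorophenyl on the carbonyl is also the same throughout, so it remains open whether these small differences would hold with a cyclohexyl or a pyridyl in its place.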